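The source may report more compounds than this note shows. Statements on the series, on what has been measured and on what is new or still open speak of the compounds shown alone.

Within the data shown here, compound 2 `Oc1ccc(-c2cc(-c3ccc(F)cc3)cc(-c3cccc(O)c3)n2)cc1` is the only compound here with a number in a functional assay on HCT-15 cells (Homo sapiens) for inhibition (on this read-out lower numbers stand for stronger inhibition and higher numbers for weaker inhibition), where compound 2 gives 5020 nM. Compound 1 `Oc1ccc(-c2cc(-c3ccc(F)cc3)cc(-c3ccccc3O)n2)cc1` in this assay gives only a limit of the assay, > 50000 nM. Among the measured compounds shown here, the one measured step, an at least 9.9-fold lower number from compound 1 to compound 2 (0.99 log units; beyond the scatter), is 3-hydroxyphenyl in place of 2-hydroxyphenyl on an aromatic carbon, and it starts from that limit. Compound 3 `Oc1ccc(-c2cc(-c3ccc(C(F)(F)F)cc3)cc(-c3cccc(O)c3)n2)cc1` arises from compound 2 by a different change: trifluoromethyl in place of fluoro on an aromatic carbon. For the measured compounds named here, no measured step touches the 4-fluorophenyl part of the shared core, so the step from compound 1 to compound 2 at another position gives no direct guide to the size or direction to expect here. Going by the values given here, with no precedent for this change, the expected step in this assay is none beyond the scatter, a 1.0-fold lower number from compound 2 to compound 3 (0.00 log units; within the scatter). Compound 3 is therefore estimated at 5000 nM, within a range from 1500 nM to 17000 nM.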

Compound 3, half-maximal inhibitory concentration: 6440 nM
For compound 3 the middle estimate is 1.3-fold (0.11 log units) below the measured one; low and high end bracket the measured number.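

In this assay, putting trifluoromethyl in place of fluoro, para to a large group, gives a 1.3-fold higher number from compound 2 to compound 3 (0.11 log units; within the scatter) and so shows no change that can be told from the scatter. Among these compounds, this is the first measured change at the 4-fluorophenyl part of the shared core, as the earlier step lay at another position and started from a limit. It shows that a group with more heavy atoms than fluoro can stand here while the inhibition of these cells stays in the same range.

From the compounds shown here alone, neither group carries a hydrogen-bond donor or acceptor, so it remains open what an amine or a carboxylic acid would do at this position. No measurement shown here bears on why fluoro and trifluoromethyl read alike.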